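The source may hold more compounds than are shown below. What is called first, only, known or untested is meant among the compounds shown, and "the series" means these compounds.

Measured compounds in an assay on L cells for inhibition of Protein-serine O-palmitoleoyltransferase porcupine (Mus musculus), read by reporter gene assay, with a stated time of 24 h; a higher number here means that more compound is needed for the effect, a lower number that less compound is needed:
compound 1 `Cc1ccc2nc(NC(=O)CNC(=O)c3nn(-c4ccccc4)c(=O)c4ccccc34)sc2c1` gives 35 nM
compound 2 `COc1ccc2nc(NC(=O)CNC(=O)c3nn(-c4ccccc4OC)c(=O)c4ccccc34)sc2c1` gives 90 nM
compound 3 `COc1ccc(-n2nc(C(=O)NCC(=O)Nc3nc4ccc(C)cc4s3)c3ccccc3c2=O)cc1` gives 25 nM

Compound 1 stands second highest of the three numbers; its nearest neighbour is compound 3, the step of a 1.4-fold lower number from compound 1 to compound 3 (0.15 log units; within the scatter) lying within the scatter, and the furthest is compound 2, whose value sits beyond the scatter above that of compound 1.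

Compound 4 `O=C(CNC(=O)c1nn(-c2ccccc2)c(=O)c2ccccc12)Nc1nccs1` differs from compound 1 by 1,3-thiazol-2-yl in place of 6-methyl-1,3-benzothiazol-2-yl on an amide-type nitrogen. Going by the values given here, no measured step bears on this change: the only step in hand, a 1.4-fold lower number from compound 1 to compound 3 (0.15 log units; within the scatter), concerns a methoxy on an aromatic carbon and leaves the amide substituent untouched, and compound 2 differs from compound 1 in two places at once. The expectation therefore rests on the size of the change alone; removing the fused six-membered ring and its methyl is a large cut, and a higher number is expected for compound 4 in this assay, with wide uncertainty. Compound 4 is estimated at 350 nM, range 80 nM to 1500 nM, which means an expected step of a 10-fold higher number from compound 1 to compound 4 (1.00 log units; beyond the scatter).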

Compound 4, half-maximal effective concentration: > 25000 nM
Compound 4: no number, only a limit; the forecaster's own chance of this, stated with the estimate: 10%; at least 71-fold (1.85 log units) between middle value and limit.
By their numbers in this assay, from the lowest: compounds 3 and 1 (each within the scatter of the next); then compound 2. At a limit, above all of these: compound 4.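

In this assay, going by these compounds alone, the substituent on the amide-type nitrogen is the first place where a single change carries a large step: an at least 710-fold higher number from compound 1 to compound 4 (2.85 log units; beyond the scatter), whereas the methoxy change on an aromatic carbon gave a 1.4-fold lower number from compound 1 to compound 3 (0.15 log units; within the scatter). At this position, 1,3-thiazol-2-yl is therefore a poor replacement for 6-methyl-1,3-benzothiazol-2-yl, so the six-membered aromatic ring of carbon only and its methyl matter together. The value for compound 4 is a limit of the assay, not a number: the limit of > 25000 nM in this assay, at which 1 of the 4 values shown sits.

This change removes the ring and the methyl at once, so the share of each cannot be separated. Open, as far as these compounds go, is whether an unsubstituted 1,3-benzothiazol-2-yl, or one carrying ethyl or a carboxylic acid in place of the methyl, would keep the number close to that of compound 1.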